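Neutral ether in place of the acid on the piperidine chain

The source may hold more compounds than are shown below. What is called first, only, known or untested is meant among the compounds shown, and "the series" means these compounds.

Compound 1 `Cn1ncc(Cl)c1-c1cc(C(=O)N[C@@H]2CNCC[C@H]2c2ccc(C(F)(F)F)cc2)oc1Cl`: 120 nM
Compound 2 `Cn1ncc(Cl)c1-c1cc(C(=O)N[C@@H]2CN[C@H](CCO)C[C@H]2c2ccc(F)c(F)c2)oc1Cl`: 460 nM
Compound 3 `Cn1ncc(Cl)c1-c1cc(C(=O)N[C@@H]2CN[C@H](CC(=O)O)C[C@H]2c2ccc(Cl)c(Cl)c2)oc1Cl`: 5120 nM

In a functional assay on OVCAR-8 cells (Homo sapiens) for antiproliferative activity (on this read-out higher numbers stand for weaker inhibition and lower numbers for stronger inhibition), compound 3 gives the highest number of the three, well beyond the scatter from compound 2 and still further from compound 1. Compound 4 `COCC[C@@H]1C[C@@H](c2ccc(Cl)c(Cl)c2)[C@H](NC(=O)c2cc(-c3c(Cl)cnn3C)c(Cl)o2)CN1` has not yet been measured in this assay. It differs from compound 3 in one place: methoxymethyl in place of carboxy on a saturated chain carbon bound to a saturated ring carbon. Since compound 2, which carries a neutral chain at the same place, gives 460 nM, a step toward stronger inhibition is expected for an 8.5-fold lower number from compound 3 to compound 4 (0.93 log units; beyond the scatter), though its size is uncertain. Compound 4 is estimated to give 600 nM, within a range from 150 nM to 2500 nM.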

Compound 4, half-maximal inhibitory concentration: 1060 nM
The estimate for compound 4 lay 1.8-fold (0.25 log units) below the measured number; the measured number falls inside the stated range.
By their numbers in this assay, from the lowest: compound 1; then compound 2; then compound 4; then compound 3.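

In this assay, going by these compounds alone, methoxymethyl in place of carboxy on a saturated chain carbon bound to a saturated ring carbon brings a 4.8-fold lower number from compound 3 to compound 4 (0.68 log units; beyond the scatter), the first comparison at this position with everything else held the same. The change keeps the heavy-atom count and removes the one hydrogen-bond donor of carboxy, so this position is sensitive to the swap. No available evidence accounts for the step. The compounds shown leave open how an amine or a plain ethyl chain would compare at this place, and so which feature of the change matters.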